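A few compounds are considered here, and "the series" means these few. Any claim that something is new, unique, unknown or untested is made for them only; others in the source may bear on it.

Compound 1 `CC(C)Cc1ccc2c(NCCCNCc3ccco3)ccnc2c1`: 9.47
Compound 2 `COc1ccc(Oc2ccc3c(NCCCNCc4cc(F)ccc4OC)ccnc3c2)cc1`: 9.28

These readings come from a physicochemical assay for acid dissociation. Compound 2 at 9.28 stands within the usual scatter of compound 1 at 9.47, although the two structures differ in more than one place. Compound 3 `COc1ccc(F)cc1CNCCCNc1ccnc2cc(Cc3ccc(F)cc3Cl)ccc12`, not yet measured, differs from compound 2 by 2-chloro-4-fluorobenzyl in place of 4-methoxyphenoxy on an aromatic carbon. Among the measured compounds shown here, no measured pair differs in one place only, so no measured step can guide the expectation. The expected change, a number 0.02 log units higher from compound 2 to compound 3 (within the scatter), lies within the scatter, and a higher read-out is no more expected than a lower one. For compound 3 the estimated value is 9.3, with an expected range of 8.9 to 9.7.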

Compound 3, acid dissociation constant: 9.47
Beside the measured number, compound 3's estimate is 0.17 log units below it; the range from low to high includes it.
By their numbers in this assay, from the lowest: compounds 2, 1 and 3 (each within the scatter of the next).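

In this assay, among the compounds shown here, the swap of 4-methoxyphenoxy for 2-chloro-4-fluorobenzyl on this aromatic carbon gives a number 0.19 log units higher from compound 2 to compound 3 (within the scatter) and is the first comparison in the set that differs in one place only. At this position the two groups are not told apart by this read-out, although the oxygen atoms of the leaving group give way to fluorine and chlorine in the entering one. Nothing available explains this result. The compounds shown leave open whether an amine or a carboxylic acid at this position would shift the number beyond the scatter.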